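Halogen swap in a cytotoxicity series on L02 cells

The source may hold more compounds than are shown below. What is called first, only, known or untested is meant among the compounds shown, and "the series" means these compounds.

Compound 1, `CN1C/C(=C\c2ccc(Cl)cc2)C(=O)/C(=C/c2cccc([N+](=O)[O-])c2)C1`: > 20000 nM
Compound 2, `CN1C/C(=C\c2ccc(Br)cc2)C(=O)/C(=C/c2cccc([N+](=O)[O-])c2)C1`: 9850 nM
Compound 3, `CN1C/C(=C\c2ccc(Cl)cc2)C(=O)/C(=C/c2ccc(C#N)cc2)C1`: 16200 nM

The three measured compounds were tested in an ADME assay on L02 cells (Homo sapiens) for cytotoxicity, read by MTT assay, with a stated time of 24 h; on this read-out higher numbers stand for weaker inhibition and lower numbers for stronger inhibition. Compound 1 reaches only the limit of this assay, > 20000 nM, and gives no number. Compound 2 gives 9850 nM, and compound 3 gives 16200 nM. Compound 2 differs from compound 1 by bromo in place of chloro on an aromatic carbon, and this change brought an at least 2.0-fold lower number from compound 1 to compound 2 (0.30 log units; that floor lies within the scatter), a step resting on (the limit of > 20000 nM in this assay, at which 1 of the 3 values shown sits). Compound 3 and compound 1 share no single counted difference; the difference between the two cores is not broken down here. Compound 3 is nearest to compound 2, their values lying within the scatter of each other.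

Compound 4, `CN1C/C(=C\c2ccc(Br)cc2)C(=O)/C(=C/c2ccc(C#N)cc2)C1`, is not yet measured. It differs from compound 3 by bromo in place of chloro on an aromatic carbon, the same change seen from compound 1 to compound 2. From compound 3 to compound 4 a step of a 1.9-fold lower number from compound 3 to compound 4 (0.28 log units; within the scatter) is expected in this assay, resting on the earlier step of an at least 2.0-fold lower number from compound 1 to compound 2 (0.30 log units; that floor lies within the scatter). Compound 4 is therefore estimated at 8500 nM, between 4000 nM and 17000 nM.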

Compound 4, half-maximal inhibitory concentration: 10500 nM
Beside the measured number, compound 4's estimate is 1.2-fold (0.09 log units) below it; the range from low to high includes it.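

In this assay, the change from 4-chlorophenyl to 4-bromophenyl on the core of compound 3 gave a 1.5-fold lower number from compound 3 to compound 4 (0.19 log units; within the scatter). Set beside the same change on the core of compound 1, the result allows only a limited comparison: the same change on two cores in this assay, an at least 2.0-fold lower number (0.30 log units; that floor lies within the scatter) from compound 1 to compound 2 and a 1.5-fold lower number (0.19 log units; within the scatter) from compound 3 to compound 4; the limit leaves it open whether they differ The second step lies within the scatter and the first is known only as a floor, so the series shows no conflict between the two cores but does not establish that the change carries a dependable effect from one core to the other, and the first step rests on a limit held by compound 1: the limit of > 20000 nM in this assay, at which 1 of the 4 values shown sits.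

The compounds shown leave open how the same halogen change would read if an amine or a carboxylic acid stood in place of the nitrile of compound 3 and compound 4. They also leave open whether a longer chain in place of the methyl on the nitrogen of the shared core would alter the step.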